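A few compounds are considered here, and "the series" means these few. Any claim that something is new, unique, unknown or untested is made for them only; others in the source may bear on it.

The compounds measured so far, with their numbers in a functional assay on NCI-H1975 cells (Homo sapiens) for inhibition, read by MTT assay, with a stated time of 72 h; a lower number here means a stronger inhibitor, a higher number a weaker inhibitor:

Compound 1 `CN1CCN(c2cc(C(F)(F)F)nc(SCc3ccc(C(F)(F)F)cc3)n2)CC1`: 23900 nM
Compound 2 `CCN1CCN(c2cc(C(F)(F)F)nc(SCc3ccc(C(F)(F)F)cc3)n2)CC1`: 15000 nM
Compound 3 `Cc1csc(Sc2cc(C(F)(F)F)nc(SCc3ccc(C(F)(F)F)cc3)n2)n1`: 5840 nM

Compound 3 has the lowest number of the three. Its separation from the other two is real: a 4.1-fold lower number from compound 1 to compound 3 (0.61 log units; beyond the scatter) and a 2.6-fold lower number from compound 2 to compound 3 (0.41 log units; beyond the scatter), both steps beyond the scatter, though only modest in size. Between compound 1 and compound 2 the step is a 1.6-fold lower number from compound 1 to compound 2 (0.20 log units; within the scatter), so those two cannot be ordered.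

The next compound, compound 4 `FC(F)(F)c1ccc(CSc2nc(Sc3ncccn3)cc(C(F)(F)F)n2)cc1`, keeps everything in compound 3 except one ring. The change is pyrimidin-2-yl in place of 4-methyl-1,3-thiazol-2-yl on a sulfur. Within the data shown here, no measured step matches this kind of swap. The two steps that end at compound 3 exchange the whole group on the aromatic carbon, a piperazine for a sulfur-linked aromatic ring, and the step from compound 3 to compound 4 keeps the sulfur link and only exchanges the ring on it. The nearest evidence therefore says little, and the expectation is a step in this assay of a 1.0-fold higher number from compound 3 to compound 4 (0.01 log units; within the scatter), which lies within the scatter. Compound 4 is estimated at 6000 nM, with a range from 2500 nM to 15000 nM.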

Compound 4, half-maximal inhibitory concentration: 14000 nM
Beside the measured number, compound 4's estimate is 2.3-fold (0.37 log units) below it; low and high end bracket the measured number.
By their numbers in this assay, from the lowest: compound 3; then compounds 4, 2 and 1 (each within the scatter of the next).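

With the sulfur link kept, a 2.4-fold higher number from compound 3 to compound 4 (0.38 log units; beyond the scatter) shows that in this assay the ring on that sulfur counts on its own, even though both rings have the same number of heavy atoms. The sulfur link does not by itself set a compound apart from the piperazines: a 1.1-fold lower number from compound 2 to compound 4 (0.03 log units; within the scatter) and a 1.7-fold lower number from compound 1 to compound 4 (0.23 log units; within the scatter) leave compound 4 within the scatter of both, while compound 3 stands clear of them. No measurement shown accounts for the difference between the two rings.

The compounds shown cannot separate the effect of the methyl from that of the ring itself, since the methyl is present only on the thiazole. They also say nothing about a plain 1,3-thiazol-2-yl, a 4-methylpyrimidin-2-yl or a phenyl on the same sulfur.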